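Swapping methoxy for chloro on the pendant phenyl ring

A few compounds are considered here, and "the series" means these few. Any claim that something is new, unique, unknown or untested is made for them only; others in the source may bear on it.

Three compounds share one core. Compound 1 `COc1cc(/C=C/C(=O)c2cccc(-n3cc(-c4ccccc4)[nH]c3=O)c2)ccc1O` gives 1510 nM in a functional assay on HCC 2998 cells (Homo sapiens) for inhibition; on this read-out higher numbers stand for weaker inhibition of growth and lower numbers for stronger inhibition of growth. Compound 3 `COc1ccc(-c2cn(-c3cccc(C(=O)/C=C/c4ccc(O)c(OC)c4)c3)c(=O)[nH]2)cc1` gives 2320 nM. Compound 2 `O=C(/C=C/c1cccc(O)c1)c1cccc(-n2cc(-c3ccc(Cl)cc3)[nH]c2=O)c1` gives 13700 nM. Compound 3 thus stands second highest of the three, close to compound 1 and far from compound 2. Among the compounds with values here, the one step that touches compound 3 is a 1.5-fold higher number from compound 1 to compound 3 (0.19 log units; within the scatter). Compound 4 `COc1cc(/C=C/C(=O)c2cccc(-n3cc(-c4ccc(Cl)cc4)[nH]c3=O)c2)ccc1O` differs from compound 3 by chloro in place of methoxy on an aromatic carbon. Within the data shown here, no measured pair shows exactly this change; compound 2 also carries a chloro but differs elsewhere as well, so its higher number cannot be pinned on the chloro alone. A modest weakening is therefore expected, a 1.5-fold higher number from compound 3 to compound 4 (0.18 log units; within the scatter), with much uncertainty. Compound 4 is estimated at 3500 nM, between 1200 nM and 10000 nM.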

Compound 4, concentration for 50% growth inhibition: 1850 nM
For compound 4 the middle estimate is 1.9-fold (0.28 log units) above the measured one; low and high end bracket the measured number.
By their numbers in this assay, from the lowest: compounds 1, 4 and 3 (each within the scatter of the next); then compound 2.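

At the position para to a large group on the pendant ring, hydrogen, chloro and methoxy cannot be told apart in this assay: chloro in place of methoxy gives a 1.3-fold lower number from compound 3 to compound 4 (0.10 log units; within the scatter), and chloro in place of hydrogen gives a 1.2-fold higher number from compound 1 to compound 4 (0.09 log units; within the scatter). Within the data shown here, the one clear change comes at the other end of the molecule, where 4-hydroxy-3-methoxyphenyl in place of 3-hydroxyphenyl gives a 7.4-fold lower number from compound 2 to compound 4 (0.87 log units; beyond the scatter), so the chloro alone does not account for the high number of compound 2. No measurement here explains either result. From the compounds shown here alone, whether an amine or a carboxylic acid at the same position would also leave the number unchanged remains open. So does whether the effect of the 3-hydroxyphenyl swap holds with hydrogen or methoxy on the pendant ring.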